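From Anilide to Benzyl Amide on a Shared Core

The compounds below may be only part of what the source reports. "The series", "measured", "known", "first", "only" and "open" are said of these compounds alone.

Compound 1 `CCc1cccc(NC(=O)c2cncc(N3CC4CC(C3)N4)c2)c1`: in an assay on membranes from Cerebral cortex for displacement of a labelled ligand from Neuronal acetylcholine receptor; alpha4/beta2 (Rattus norvegicus) (a higher number here means a weaker inhibitor, a lower number a stronger inhibitor), compound 1 gives 1.3 nM.
Compound 2 `O=C(Nc1cccc(Cl)c1)c1cncc(N2CC3CC(C2)N3)c1`: in this assay compound 2 gives 0.042 nM.

Among the compounds with values here, compound 2 holds the lower of the two numbers in this assay, and the only measured step is a 31-fold lower number from compound 1 to compound 2 (1.49 log units; beyond the scatter). Compound 3 `O=C(NCc1ccccc1)c1cncc(N2CC3CC(C2)N3)c1` carries benzyl in place of 3-chlorophenyl on an amide-type nitrogen. Within the data shown here, no measured step touches the amide nitrogen, so that step gives little guidance here, beyond showing that the chloro-bearing ring, now gone, carried much of the gain in a 31-fold lower number from compound 1 to compound 2 (1.49 log units; beyond the scatter). A weaker number is therefore expected for compound 3, estimated at 4 nM within 0.4 nM to 40 nM, a step of a 95-fold higher number from compound 2 to compound 3 (1.98 log units; beyond the scatter).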

Compound 3, inhibition constant: 1.8 nM
Compound 3: the middle estimate sits 2.2-fold (0.35 log units) above what was measured, and the stated range covers the measured number.
By their numbers in this assay, from the lowest: compound 2; then compounds 1 and 3 (each within the scatter of the next).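

Replacing 3-chlorophenyl with benzyl on the amide-type nitrogen gives a 43-fold higher number from compound 2 to compound 3 (1.63 log units; beyond the scatter) in this assay even though both groups carry one six-membered aromatic ring of carbon only, so an aromatic ring alone does not preserve the low number of compound 2. Benzyl in place of 3-ethylphenyl gives a 1.4-fold higher number from compound 1 to compound 3 (0.14 log units; within the scatter) and so sets the 3-chlorophenyl compound apart among these three. No evidence is available to account for this difference.

Going by these compounds, what 3-chlorobenzyl would give remains open. So does the effect of unsubstituted phenyl or a longer chain such as phenethyl on this nitrogen.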